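Benzyl for phenyl on the ring nitrogen: second pair

The compounds below may be only part of what the source reports. "The series", "measured", "known", "first", "only" and "open" are said of these compounds alone.

Compound 1 `N#Cc1ncn(-c2ccc(F)cc2)c1/N=C/c1ccc([N+](=O)[O-])cc1` and compound 2 `COc1cc(/C=N/c2c(C#N)ncn2-c2ccc(F)cc2)ccc1O` share a core; the difference between the two is not broken down here. In a functional assay on A549 cells (Homo sapiens) for antiproliferative activity, read by MTT assay, with a stated time of 48 h (on this read-out lower numbers stand for stronger inhibition and higher numbers for weaker inhibition), compound 1 gives 18100 nM and compound 2 gives 13600 nM, the two numbers lying within the scatter of each other. Compound 3 `N#Cc1ncn(Cc2ccc(F)cc2)c1/N=C/c1ccc([N+](=O)[O-])cc1` carries 4-fluorobenzyl in place of 4-fluorophenyl on an aromatic nitrogen; in this assay compound 3 gives 2020 nM, a step of a 9.0-fold lower number from compound 1 to compound 3 (0.95 log units; beyond the scatter). Compound 4 `COc1cc(/C=N/c2c(C#N)ncn2Cc2ccc(F)cc2)ccc1O` carries the same change on compound 2: 4-fluorobenzyl in place of 4-fluorophenyl on an aromatic nitrogen, with the place described in identical words. Going by the values given here, compound 4 is expected to show a step of a 6.8-fold lower number from compound 2 to compound 4 (0.83 log units; beyond the scatter) in this assay because the one measured instance of this change gave a 9.0-fold lower number from compound 1 to compound 3 (0.95 log units; beyond the scatter). Compound 2 starts at 13600 nM, within scatter of compound 1. The estimate for compound 4 is 2000 nM, ranging from 700 nM to 6000 nM, resting on a single pair only.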

Compound 4, half-maximal inhibitory concentration: 10900 nM
Compound 4: middle estimate off by 5.5-fold (0.74 log units), on the low side; the measured number lies above the stated range.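

In this assay, 4-fluorobenzyl in place of 4-fluorophenyl on the aromatic nitrogen gives a 1.2-fold lower number from compound 2 to compound 4 (0.10 log units; within the scatter), so the size of the step seen on the core of compound 1 does not carry over to the core of compound 2: the same change on two cores in this assay, a 9.0-fold lower number (0.95 log units; beyond the scatter) from compound 1 to compound 3 and a 1.2-fold lower number (0.10 log units; within the scatter) from compound 2 to compound 4, 7.2-fold (0.86 log units) apart, beyond the scatter of two such steps

The size of this step therefore cannot be transferred from one of these two cores to the other. Two pairs do not show which difference between the cores matters, or what the change would do on a third core.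

On these data alone, it remains open which of the two outcomes is more usual across the series. Also open, as far as these compounds go, is how a 2-(4-fluorophenyl)ethyl chain, an unsubstituted benzyl or a chain ending in an amine on the same nitrogen would read on either core.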